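A Second Methoxy Group and the Expected Effect on Cytotoxicity

The source may report more compounds than this note shows. Statements on the series, on what has been measured and on what is new or still open speak of the compounds shown alone.

Compound 2 `COc1ccc(-c2cc(-c3ccc4cc(F)ccc4n3)n(-c3ccccc3)n2)cc1` stands highest of the two compounds measured in an ADME assay on Huh-7 cells (Homo sapiens) for cytotoxicity, read by XTT assay, with a stated time of 3 days, tested at 200 uM (on this read-out higher numbers stand for a weaker effect at the one concentration tested and lower numbers for a stronger effect), where compound 2 gives 98.9%; compound 1 `Fc1ccc(-c2cc(-c3ccc4cc(F)ccc4n3)n(-c3ccccc3)n2)cc1` gives 87.5%. Going by the values given here, the single measured step, a number 11.4 percentage points higher from compound 1 to compound 2 (beyond the scatter), concerns a different place and a different leaving group. Compound 3 `COc1ccc(-c2cc(-c3ccc4cc(F)ccc4n3)n(-c3ccc(OC)cc3)n2)cc1` differs from compound 2 in one place: methoxy in place of hydrogen on an aromatic carbon. Among the compounds with values here, no measured step bears directly on this change. Compound 2 already sits near the top of the scale, and the step of a number 2.9 percentage points lower from compound 2 to compound 3 (within the scatter) is therefore expected to lie within the scatter. Compound 3 is estimated at 96%, between 84% and 105%.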

Compound 3, a percentage reported as activity, at one concentration (the size of the read-out at that concentration, not a potency): 98.4%
For compound 3 the middle estimate is 2.4 percentage points below the measured one; the range from low to high includes it.
By their numbers in this assay, from the lowest: compound 1; then compounds 3 and 2 (each within the scatter of the next).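

In this assay, methoxy in place of hydrogen on this aromatic carbon gives a number 0.5 percentage points lower from compound 2 to compound 3 (within the scatter), so compound 2 and compound 3 cannot be told apart. The earlier step replaced fluoro with methoxy at another place, whereas this one shows that a methoxy group can be added to the ring on nitrogen, para to a large group, with no difference beyond the scatter. Nothing available explains this result. From the compounds shown here alone, it remains open whether an amine, a carboxylic acid or a longer chain such as ethoxy at this place would also stay within the scatter of compound 2.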